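Two stereocentres inverted in a dose series

This account rests on a few compounds, and the source may have more. Where it says the series, first, only, none or still open, it means among the compounds named here.

- Compound 1 `CCCC[C@](C)(OC)[C@H](O)/C=C/C1[C@H](O)C[C@H](O)[C@@H]1C/C=C\CCCC(=O)OC` at 1.5 mg/kg
- Compound 2 `CCCC[C@@](C)(OC)[C@H](O)/C=C/C1[C@H](O)C[C@H](O)[C@@H]1C/C=C\CCCC(=O)OC` at 0.6 mg/kg

In a functional assay on the whole organism (Cricetulus griseus) with Cricetinae gen. sp. as the target (a lower number here means that less compound is needed, a higher number that more compound is needed for the effect), compound 2 has the lower of the two numbers, 0.6 mg/kg as measured. Compound 3 `CCCC[C@](C)(OC)[C@@H](O)/C=C/C1[C@H](O)C[C@H](O)[C@@H]1C/C=C\CCCC(=O)OC` keeps the atoms and bonds of compound 2 but differs in configuration (the two compounds have the same atoms and bonds; at least one stereo element is drawn with a configuration in one of them and without one in the other: 2 of 8 stereo elements differ; a stereocentre at a saturated chain carbon is drawn R in compound 2 and S in compound 3; a stereocentre at a saturated chain carbon is drawn R in compound 2 and S in compound 3). Within the data shown here, the one measured step bearing on this is a 2.5-fold lower number from compound 1 to compound 2 (0.40 log units; beyond the scatter), which also concerns a stereocentre at a saturated chain carbon. Going back the other way would raise the number, and the second stereocentre has no measured step. A higher number is therefore expected, and the estimated change is a 6.7-fold higher number from compound 2 to compound 3 (0.82 log units; beyond the scatter) in size. For compound 3 the expected value is 4 mg/kg, with 1 mg/kg to 25 mg/kg as its estimated range.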

Compound 3, dose for half-maximal effect: > 4 mg/kg
Compound 3 was reported as a limit (the forecaster's own chance of this, stated with the estimate: 10%); the middle value lies on the limit itself.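

In this assay compound 3 gives > 4 mg/kg, which is a limit of the assay. The second stereocentre at a saturated chain carbon now has a step of its own, an at least 2.6-fold higher number from compound 1 to compound 3 (0.42 log units; beyond the scatter), so configuration at this carbon also matters, not only at the centre that separates the first pair. With both centres changed the step is an at least 6.6-fold higher number from compound 2 to compound 3 (0.82 log units; beyond the scatter), and both steps give only a lower bound on size: the limit of > 4 mg/kg in this assay, at which 1 of the 3 values shown sits.

As far as these compounds go, how far the number of compound 3 lies past its limit stays open. So does whether these stereocentres would have the same weight with a carboxylic acid in place of the methyl ester.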